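Series notes: pyrazoline-type set, step from compound 3 to compound 4

A few compounds are considered here, and "the series" means these few. Any claim that something is new, unique, unknown or untested is made for them only; others in the source may bear on it.

Measured compounds:
compound 1 `Oc1ccc(C2CC(c3ccccc3O)=NN2c2ccc(Cl)cc2)cc1` – 92%
compound 2 `COc1ccccc1C1=NN(c2ccc(Cl)cc2)C(c2ccc(O)cc2)C1` – 68.4%
compound 3 `CCOc1ccccc1C1=NN(c2ccc(Cl)cc2)C(c2ccc(O)cc2)C1` – 42.8%

In an assay on isolated protein for inhibition of protein kinase C zeta type (Homo sapiens), with a stated time of 4 min, tested at 62.5 uM (on this read-out lower numbers stand for less inhibition and higher numbers for more inhibition at the one concentration tested (going by the name of the read-out)), compound 1 gives 92% and compound 3 gives 42.8%, the lowest of the three numbers. The nearest number belongs to compound 2, and the gap is a number 25.6 percentage points lower from compound 2 to compound 3 (beyond the scatter); the furthest belongs to compound 1, with a number 49.2 percentage points lower from compound 1 to compound 3 (beyond the scatter). The two single steps that build this gap are a number 23.6 percentage points lower from compound 1 to compound 2 (beyond the scatter) and a number 25.6 percentage points lower from compound 2 to compound 3 (beyond the scatter), both beyond the scatter and of similar size, so on these three compounds each enlargement of the group on the oxygen on the aromatic ring has lowered the read-out.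

Compound 4 `CC1=NN(c2ccc(Cl)cc2)C(c2ccc(O)cc2)C1` is not yet measured. Its change from compound 3 is methyl in place of 2-ethoxyphenyl on a carbon with a double bond to nitrogen, the whole aryl group being exchanged for methyl on a carbon with a double bond to nitrogen. Among the measured compounds shown here, none of the measured steps touches this position; all three concern only the oxygen on the aromatic ring, so they do not tell the direction here. The expectation is therefore wide: a step of a number 2.8 percentage points lower from compound 3 to compound 4 (within the scatter) is estimated, with no firm direction. Compound 4 is expected to give about 40%, within a range from 10% to 72% in this assay.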

Compound 4, a percentage reported as inhibition, at one concentration (the size of the read-out at that concentration, not a potency): 58.8%
Compound 4: middle estimate off by 18.8 percentage points, on the low side, and the stated range covers the measured number.
By their numbers in this assay, from the lowest: compound 3; then compounds 4 and 2 (each within the scatter of the next); then compound 1.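

At the carbon with a double bond to nitrogen, the whole aryl group can give way to methyl without losing the read-out in this assay: compound 4 still gives 58.8%, so an aryl group at this place is not needed for a number of this size. The same exchange reads differently according to the group that leaves, with a number 16 percentage points higher from compound 3 to compound 4 (beyond the scatter) for 2-ethoxyphenyl, a number 9.6 percentage points lower from compound 2 to compound 4 (within the scatter) for 2-methoxyphenyl and a number 33.2 percentage points lower from compound 1 to compound 4 (beyond the scatter) for 2-hydroxyphenyl; among these three aryl groups, 2-hydroxyphenyl alone stands clearly above methyl, 2-ethoxyphenyl stands clearly below it, and 2-methoxyphenyl cannot be told apart from it. Nothing measured here bears on the reason for this ranking.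

As far as these compounds go, whether a longer chain such as butyl, an amine or a carboxylic acid at this carbon would give a number nearer that of compound 4 or of compound 1 stays open. Also open, from the compounds shown here alone, is what the 4-chlorophenyl and 4-hydroxyphenyl groups contribute, as both are the same in all four compounds.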